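Second chloro on the 3-chlorophenyl group of compound 3

A few compounds are considered here, and "the series" means these few. Any claim that something is new, unique, unknown or untested is made for them only; others in the source may bear on it.

In a functional assay on HCT-116 cells (Homo sapiens) for inhibition, read by MTT assay, with a stated time of 48 h (a higher number here means a weaker inhibitor, a lower number a stronger inhibitor), compound 1 (`O=C(Nc1cccc(Cl)c1)Nc1ccc(-c2cc(=O)c3ccccc3o2)c(Cl)c1`) gives 25400 nM, compound 2 (`CCc1ccc2oc(-c3ccc(NC(=O)Nc4cccc(Cl)c4)cc3Cl)cc(=O)c2c1`) gives 27900 nM and compound 3 (`COc1ccc2oc(-c3ccc(NC(=O)Nc4cccc(Cl)c4)cc3Cl)cc(=O)c2c1`) gives 9600 nM, the lowest of the three numbers. Compound 4 (`COc1ccc2oc(-c3ccc(NC(=O)Nc4ccc(Cl)c(Cl)c4)cc3Cl)cc(=O)c2c1`) turns the 3-chlorophenyl of compound 3 into 3,4-dichlorophenyl: chloro in place of hydrogen on an aromatic carbon. Within the data shown here, no measured step touches this group. The nearest guides are ethyl, with a 1.1-fold higher number from compound 1 to compound 2 (0.04 log units; within the scatter), and methoxy, with a 2.6-fold lower number from compound 1 to compound 3 (0.42 log units; beyond the scatter) and a 2.9-fold lower number from compound 2 to compound 3 (0.46 log units; beyond the scatter). These bear on size only, and the data give no firm direction. A small step is therefore expected, and the expected change is a 1.2-fold lower number from compound 3 to compound 4 (0.08 log units; within the scatter). The estimated value for compound 4 is 8000 nM, with an expected range of 3000 nM to 20000 nM.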

Compound 4, half-maximal inhibitory concentration: 8600 nM
The estimate for compound 4 lay 1.1-fold (0.03 log units) below the measured number; the measured number falls inside the stated range.
By their numbers in this assay, from the lowest: compounds 4 and 3 (each within the scatter of the next); then compounds 1 and 2 (each within the scatter of the next).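

In this assay, the step from 3-chlorophenyl to 3,4-dichlorophenyl reads a 1.1-fold lower number from compound 3 to compound 4 (0.05 log units; within the scatter), so a chloro group at this place, ortho to a chloro group and para to a large group, leaves the number within the scatter. The earlier steps shown here gave no reading on this aromatic ring, and this is its first. Nothing at hand offers an explanation for this result.

As far as these compounds go, whether an amine or a carboxylic acid at this place would also leave the number unmoved stays open. So does whether the same chloro step would read alike on compound 1 or compound 2.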